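The source may report more compounds than this note shows. Statements on the series, on what has been measured and on what is new or still open speak of the compounds shown alone.

Measured so far in an assay on cells for displacement of a labelled ligand from D(4) dopamine receptor (Homo sapiens); a higher number here means a weaker inhibitor, a lower number a stronger inhibitor: compound 1 `COc1cc2c(cc1O)CN(CCCCNC(=O)c1ccc(I)cc1)CC2`, 1500 nM; compound 2 `COc1cc2c(cc1O)CN(CCCCNC(=O)c1ccncc1)CC2`, 1400 nM.

Compound 1 and compound 2 sit together in this assay: a 1.1-fold lower number from compound 1 to compound 2 (0.03 log units; within the scatter). The unmeasured compound 3 `COc1cc2c(cc1O)CN(CCCCNC(=O)c1ccc(Br)cc1)CC2` differs from compound 1 by bromo in place of iodo on an aromatic carbon. Within the data shown here, the only measured step, pyridin-4-yl in place of 4-iodophenyl, is a far larger change than this halogen swap, and it left this assay within the scatter; no step exchanging one halogen for another has been measured. A small move is therefore expected: compound 3 is expected to give about 1500 nM in this assay, between 700 nM and 3200 nM, an expected step of no change at the digits printed from compound 1 to compound 3 (within the scatter).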

Compound 3, inhibition constant: 350 nM
Estimate against measurement, compound 3: 4.3-fold (0.63 log units) above; measured number outside the range, below it.
By their numbers in this assay, from the lowest: compound 3; then compounds 2 and 1 (each within the scatter of the next).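

In this assay the halogen on this aromatic carbon, para to a large group, is not interchangeable: bromo in place of iodo gives a 4.3-fold lower number from compound 1 to compound 3 (0.63 log units; beyond the scatter) and so separates two compounds that differ by one atom. The earlier pair showed no separation, yet 4-bromophenyl in place of pyridin-4-yl gives a 4.0-fold lower number from compound 2 to compound 3 (0.60 log units; beyond the scatter) so the group on the carbonyl can matter here. Nothing available explains this difference between bromo and iodo.

Two halogens cannot define a trend. From the compounds shown here alone, whether chloro or fluoro on the same carbon would give a number nearer that of compound 3 or compound 1 remains open.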